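A few compounds are considered here, and "the series" means these few. Any claim that something is new, unique, unknown or untested is made for them only; others in the source may bear on it.

Measured so far in a functional assay on MDA-MB-435S cells (Homo sapiens) for cytotoxicity, read by MTT assay; a higher number here means a weaker inhibitor, a lower number a stronger inhibitor:
- compound 1 `CCOC(=O)C(C)Oc1cc(O)c2c(=O)c(O)c(-c3ccc(OC)cc3)oc2c1CC=C(C)C` gives 2500 nM
- compound 2 `CCOC(=O)COc1cc(O)c2c(=O)c(O)c(-c3ccc(OC)cc3)oc2c1CC=C(C)C` gives 5300 nM

Among the measured compounds shown here, compound 2 stands at the higher of the two numbers in this assay; the only measured step, a 2.1-fold higher number from compound 1 to compound 2 (0.33 log units; beyond the scatter), is a modest one lying just beyond the scatter.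

Compound 3 `COc1ccc(-c2oc3c(CC=C(C)C)c(OCCCC(=O)O)cc(O)c3c(=O)c2O)cc1` differs from compound 2 in one place: 2-carboxyethyl in place of ethoxycarbonyl on a saturated chain carbon bound to an oxygen on an aromatic ring. For the measured compounds named here, no measured step bears directly on this change; the single step of a 2.1-fold higher number from compound 1 to compound 2 (0.33 log units; beyond the scatter) concerns only the chain carbon bound to the carbonyl carbon, not the ester itself, and so gives little guidance beyond showing that changes at this side chain have so far moved the number modestly in this assay. Rearranging the same atoms into a 3-carboxypropoxy chain is a larger alteration than that step, and a step at least as large is expected, more likely toward a higher number than a lower one.

For compound 3 the expected value in this assay is 9000 nM, within 3000 nM to 27000 nM; this estimate corresponds to a 1.7-fold higher number from compound 2 to compound 3 (0.23 log units; within the scatter).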

Compound 3, half-maximal inhibitory concentration: 12700 nM
For compound 3 the middle estimate is 1.4-fold (0.15 log units) below the measured one; the measured number falls inside the stated range.
By their numbers in this assay, from the lowest: compound 1; then compound 2; then compound 3.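

In this assay, among the compounds shown here, 3-carboxypropoxy in place of (ethoxycarbonyl)methoxy on the shared core gives a 2.4-fold higher number from compound 2 to compound 3 (0.38 log units; beyond the scatter) and is the first reading of a change to the ester end of this side chain, whereas the earlier step touched only the chain carbon bound to the carbonyl carbon. Taken together at this oxygen, 3-carboxypropyl in place of 1-(ethoxycarbonyl)ethyl gives a 5.1-fold higher number from compound 1 to compound 3 (0.71 log units; beyond the scatter), so both single changes along this series and the combined one point toward a higher number, with every step still modest. No evidence on hand accounts for these shifts.

Compound 3 carries both a carboxylic acid and a longer chain, so the compounds shown do not separate the two. As far as these compounds go, how an amide or an amine at the chain end would read at this position remains open.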